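A few compounds are considered here, and "the series" means these few. Any claim that something is new, unique, unknown or untested is made for them only; others in the source may bear on it.

In an in vitro functional assay on HEK285-7 cells for antagonist activity at prostaglandin D2 receptor 2 (Homo sapiens), read by BRET and beta-arrestin recruitment (a lower number here means a stronger inhibitor, a higher number a weaker inhibitor), compound 1 `O=C(O)Cc1sc(C(c2ccc(F)cc2)c2ccc(F)cc2)nc1-c1cccc(F)c1` gives 18 nM, compound 2 `CS(=O)(=O)Nc1cccc(-c2nc(C(c3ccc(F)cc3)c3ccc(F)cc3)sc2CC(=O)O)c1` gives 370 nM, and compound 3 `O=C(O)Cc1sc(C(c2ccc(F)cc2)c2ccc(F)cc2)nc1-c1ccco1` gives 140 nM, the second highest of the three numbers. The measured steps are a 21-fold higher number from compound 1 to compound 2 (1.31 log units; beyond the scatter), a 7.8-fold higher number from compound 1 to compound 3 (0.89 log units; beyond the scatter) and a 2.6-fold lower number from compound 2 to compound 3 (0.42 log units; beyond the scatter). Compound 4 `O=C(O)Cc1sc(C(c2ccc(F)cc2)c2ccc(F)cc2)nc1-c1cc(F)nc(F)c1` differs from compound 3 in one place: 2,6-difluoropyridin-4-yl in place of furan-2-yl on an aromatic carbon. Among the measured compounds shown here, the step of a 7.8-fold higher number from compound 1 to compound 3 (0.89 log units; beyond the scatter) bears most on this change, as it exchanged a six-membered fluorinated ring for the five-membered furan-2-yl; compound 4 brings back a six-membered ring bearing fluorines, though with a ring nitrogen that no measured compound carries. A modest fall is therefore expected, a 3.1-fold lower number from compound 3 to compound 4 (0.49 log units; beyond the scatter), with wide uncertainty. Compound 4 is estimated at 45 nM, within 12 nM to 160 nM.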

Compound 4, half-maximal inhibitory concentration: 110 nM
The estimate for compound 4 lay 2.4-fold (0.39 log units) below the measured number; the range from low to high includes it.
By their numbers in this assay, from the lowest: compound 1; then compounds 4 and 3 (each within the scatter of the next); then compound 2.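

On the aromatic carbon next to the ring nitrogen, 2,6-difluoropyridin-4-yl and furan-2-yl cannot be told apart (a 1.3-fold lower number from compound 3 to compound 4 (0.10 log units; within the scatter)), so a six-membered ring bearing fluorines does not by itself recover the number given by 3-fluorophenyl. That group keeps its lead over the new ring (a 6.1-fold higher number from compound 1 to compound 4 (0.79 log units; beyond the scatter)), while 3-(methanesulfonamido)phenyl remains behind it (a 3.4-fold lower number from compound 2 to compound 4 (0.53 log units; beyond the scatter)). No evidence here gives a reason for these differences.

On these data alone, whether the ring nitrogen or the two fluorines set the gap to 3-fluorophenyl stays open; pyridin-4-yl and 3,5-difluorophenyl would separate the two.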